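Replacing the Carbamoyl Group of Compound 2

This account rests on a few compounds, and the source may have more. Where it says the series, first, only, none or still open, it means among the compounds named here.

Compound 1 `C=CCn1c(=O)n(CCCCO)c2nc(N)nc(O)c21`: 12%
Compound 2 `NC(=O)Cn1c(=O)n(C2OC(CO)[C@@H](O)[C@H]2O)c2nc(N)nc(O)c21`: 32%
Compound 3 `Cn1c(=O)n2c3c1c(=O)nc(N)n3CC1OC2[C@H](O)[C@@H]1O`: 9%

On a functional assay on the whole organism (B cells) with Mus musculus as the target (on this read-out higher numbers stand for larger maximal responses and lower numbers for smaller maximal responses), compound 2 stands highest of the three measured compounds. Compound 1 lies lower by a gap beyond the usual scatter, and compound 3 lies lower still, also beyond the scatter. The next compound, compound 4 `N#Cc1ccc(Cn2c(=O)n(C3OC(CO)[C@@H](O)[C@H]3O)c3nc(N)nc(O)c32)cc1`, differs from compound 2 in a single place: 4-cyanophenyl in place of carbamoyl on a saturated chain carbon bound to an aromatic nitrogen. Among the measured compounds shown here, no measured pair shows this change, so there is no step from which its size or direction could be read. With nothing pointing either way, the step of a number 2 percentage points lower from compound 2 to compound 4 (within the scatter) is expected to stay within the scatter and to carry no clear direction. Compound 4 is therefore estimated at 30%, with a range from 10% to 55%.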

Compound 4, largest response reached (reported as maximal response), in percent of the reference or control that the assay uses: 50%
Compound 4: the middle estimate sits 20 percentage points below what was measured; low and high end bracket the measured number.
By their numbers in this assay, from the lowest: compounds 3 and 1 (each within the scatter of the next); then compound 2; then compound 4.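

In this assay the exchange of carbamoyl for 4-cyanophenyl gives a number 18 percentage points higher from compound 2 to compound 4 (beyond the scatter) and so offers the first direction read at this place. The saturated chain carbon bound to an aromatic nitrogen thus carries a six-membered aromatic ring of carbon only, with its hydrogen-bond donor count at zero, and the maximal response still rises. Nothing at hand explains this rise. On these data alone, whether it belongs to the nitrile or to the aromatic ring stays open, and so does how an unsubstituted phenyl, a 4-methoxyphenyl or a carboxylic acid would read here.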